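Swapping the aryl group on the amine of a cytotoxic lactone

The source may hold more compounds than are shown below. What is called first, only, known or untested is meant among the compounds shown, and "the series" means these compounds.

Compound 1, `C=C1[C@@H](OC(C)=O)C[C@@H]2[C@](C)(CO[Si](C)(C)C(C)(C)C)[C@H](OC(C)=O)CC[C@@]2(C)[C@@H]1C[C@@H](Nc1ccc(OC)cc1)C1=CCOC1=O`, was tested in a functional assay on KB cells (Homo sapiens) for cytotoxicity, read by sulforhodamine B assay (on this read-out higher numbers stand for weaker inhibition and lower numbers for stronger inhibition), where compound 1 gives 5630 nM, the lowest of the two numbers measured. Compound 2, `C=C1[C@@H](OC(C)=O)C[C@@H]2[C@](C)(COC=O)[C@H](OC(C)=O)CC[C@@]2(C)[C@@H]1C[C@@H](Nc1ccc(OC)cc1)C1=CCOC1=O`, gives 32700 nM in this assay; the step of a 5.8-fold higher number from compound 1 to compound 2 (0.76 log units; beyond the scatter) changed the group on an oxygen on a saturated carbon, not the amine. Compound 3, `C=C1[C@@H](OC(C)=O)C[C@@H]2[C@](C)(CO[Si](C)(C)C(C)(C)C)[C@H](OC(C)=O)CC[C@@]2(C)[C@@H]1C[C@@H](Nc1ccccc1C(=O)O)C1=CCOC1=O`, differs from compound 1 by 2-carboxyphenyl in place of 4-methoxyphenyl on an amine nitrogen. Going by the values given here, no measured step touches this position, so the expected step of a 1.6-fold higher number from compound 1 to compound 3 (0.20 log units; within the scatter) rests on no direct precedent and is given a wide span. Compound 3 is estimated at 9000 nM, within 2000 nM to 40000 nM.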

Compound 3, half-maximal inhibitory concentration: 6050 nM
Beside the measured number, compound 3's estimate is 1.5-fold (0.17 log units) above it; the range from low to high includes it.
By their numbers in this assay, from the lowest: compounds 1 and 3 (each within the scatter of the next); then compound 2.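

Going by these compounds alone, this is the first measured change at the amine nitrogen. In this assay, putting 2-carboxyphenyl in place of 4-methoxyphenyl gives (a 1.1-fold higher number from compound 1 to compound 3 (0.03 log units; within the scatter)), so the read-out does not tell compound 1 and compound 3 apart, even though the entering group carries a hydrogen-bond donor and the leaving group carries none. Nothing available explains this result. The compounds shown leave open whether a saturated chain such as ethyl, or a phenyl ring bearing an amine, would also give a similar number on this nitrogen. They also leave open whether a nitrogen with no aryl group would do so.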